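The compounds below may be only part of what the source reports. "The series", "measured", "known", "first", "only" and "open" are said of these compounds alone.

Working notes on the shared core `N#CC1=C(N)Oc2c(N)cc3nc4ccccc4nc3c2C12C(=O)N(Cc1cnnn1-c1ccccc1Br)c1ccccc12` in a functional assay on A549 cells (Homo sapiens) for antiproliferative activity, read by MTT assay, with a stated time of 48 h; on this read-out lower numbers stand for stronger inhibition and higher numbers for weaker inhibition: compound 1 gives 27400 nM. Compound 2 `CCOc1ccc(-n2nncc2CN2C(=O)C3(C(C#N)=C(N)Oc4c(N)cc5nc6ccccc6nc5c43)c3ccccc32)cc1` returns only the limit > 50000 nM. Compound 3 `N#CC1=C(N)Oc2c(N)cc3nc4ccccc4nc3c2C12C(=O)N(Cc1cnnn1-c1c(F)cccc1F)c1ccccc12` likewise returns only the limit > 50000 nM. Compound 3 thus stands at the floor of the numbers shown, (the limit of > 50000 nM in this assay, at which 2 of the 3 values shown sit). The steps of an at least 1.8-fold higher number from compound 1 to compound 3 (0.26 log units; that floor lies within the scatter) and an at least 1.8-fold higher number from compound 1 to compound 2 (0.26 log units; that floor lies within the scatter) reach only that floor, and a step that the two limits leave unreadable from compound 2 to compound 3. Compound 4 `Cc1ccc(-n2nncc2CN2C(=O)C3(C(C#N)=C(N)Oc4c(N)cc5nc6ccccc6nc5c43)c3ccccc32)cc1Cl` is the next step, (3-chloro-4-methylphenyl in place of 2,6-difluorophenyl on an aromatic nitrogen). With no readable movement among the measured steps, no change beyond the scatter is expected in this assay for this change. Compound 4 is expected at 45000 nM, within 15000 nM to 150000 nM. That corresponds to an expected step of an at least 1.1-fold lower number from compound 3 to compound 4 (0.04 log units; that floor lies within the scatter).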

Compound 4, half-maximal inhibitory concentration: 11800 nM
Estimate against measurement, compound 4: 3.8-fold (0.58 log units) above; the whole stated range lies above it.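

In this assay, this position now shows its first movement beyond the scatter, with 3-chloro-4-methylphenyl giving an at least 4.2-fold lower number from compound 3 to compound 4 (0.62 log units; beyond the scatter) and an at least 4.2-fold lower number from compound 2 to compound 4 (0.62 log units; beyond the scatter). The same group also gives a 2.3-fold lower number from compound 1 to compound 4 (0.37 log units; beyond the scatter), and this step rests on two measured numbers rather than a limit. The 2,6-difluorophenyl and 3-chloro-4-methylphenyl groups carry the same heavy-atom count, so that count alone does not set the value, while the other partners remain limits: the limit of > 50000 nM in this assay, at which 2 of the 4 values shown sit.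

The compounds shown do not separate the contribution of the chlorine from that of the methyl. Going by these compounds, how an amine or a carboxylic acid on this phenyl ring would read remains open.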